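This account rests on a few compounds, and the source may have more. Where it says the series, first, only, none or still open, it means among the compounds named here.

Measured compounds:
Compound 1 `C#CCSc1nc(NCCC(C)C)c2ccncc2n1` — in a functional assay on MGC-803 cells (Homo sapiens) for inhibition, read by MTT assay, with a stated time of 72 h (on this read-out higher numbers stand for weaker inhibition and lower numbers for stronger inhibition), compound 1 gives > 80000 nM, a limit of the assay rather than a number.
Compound 2 `C#CCSc1nc(Nc2ccc(C)cc2)c2ccncc2n1` — in this assay compound 2 gives 8090 nM.

Going by the values given here, compound 2 thus holds the only number recorded in this assay; the other value, (the limit of > 80000 nM in this assay, at which 1 of the 2 values shown sits), is a limit. Among the compounds with values here, the one measured step, an at least 9.8-fold lower number from compound 1 to compound 2 (0.99 log units; beyond the scatter), exchanges isopentyl for 4-methylphenyl on the ring nitrogen. Compound 3 `C#CCSc1nc(Nc2ccc(F)cc2)c2ccncc2n1` differs from compound 2 by fluoro in place of methyl on an aromatic carbon. That measured step replaces a whole chain by an aromatic ring, while the change from compound 2 to compound 3 swaps one small group for another on the same aromatic carbon, so the step bears only loosely on it. Compound 3 is expected to remain close to compound 2 in this assay, with a change of a 1.2-fold higher number from compound 2 to compound 3 (0.09 log units; within the scatter), within the scatter. Compound 3 is therefore estimated at 10000 nM, with a range from 3000 nM to 30000 nM.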

Compound 3, half-maximal inhibitory concentration: 15800 nM
Beside the measured number, compound 3's estimate is 1.6-fold (0.20 log units) below it, and the stated range covers the measured number.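

In this assay, the change of methyl to fluoro on this aromatic carbon, para to a large group, gives a 2.0-fold higher number from compound 2 to compound 3 (0.29 log units; within the scatter), so the two groups cannot be told apart here. With 4-fluorophenyl in place of isopentyl the result is an at least 5.0-fold lower number from compound 1 to compound 3 (0.70 log units; beyond the scatter), which shows that the lower number seen with 4-methylphenyl does not depend on the methyl group itself. Compound 1 stands at a limit of the assay and not at a number, so this step gives only a bound: the limit of > 80000 nM in this assay, at which 1 of the 3 values shown sits.

From the compounds shown here alone, it remains open whether a larger group on this carbon, such as trifluoromethyl, methoxy or a carboxylic acid, would move the number beyond the scatter. Going by these compounds, it is also open how an amine on the same ring, or the same groups on another of its carbons, would read.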